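Chloro to methoxy on the arylidene ring of a cyclohexanone series

The source may hold more compounds than are shown below. What is called first, only, known or untested is meant among the compounds shown, and "the series" means these compounds.

The shared core carries two arylidene arms on a cyclohexanone. Compound 1 `COc1ccc(/C=C2\CCC/C(=C\c3ccccc3Cl)C2=O)cc1OC` gives 10400 nM in a functional assay on MCF7 cells (Homo sapiens) for cytotoxicity, read by MTT assay, with a stated time of 72 h; on this read-out lower numbers stand for stronger inhibition and higher numbers for weaker inhibition. Compound 2 `COc1ccccc1/C=C1\CCC/C(=C\c2ccc(OC)c(OC)c2)C1=O` gives 8000 nM and differs from compound 1 by methoxy in place of chloro on an aromatic carbon; the step is a 1.3-fold lower number from compound 1 to compound 2 (0.11 log units; within the scatter). Compound 3 `COc1ccc(/C=C2\CCC/C(=C\c3ccc(O)c(Cl)c3)C2=O)cc1OC` gives 12300 nM; its core differs from that of compound 1 by 3-chloro-4-hydroxyphenyl in place of 2-chlorophenyl on a double-bonded chain carbon bound to a double-bonded ring carbon, with a 1.2-fold higher number from compound 1 to compound 3 (0.07 log units; within the scatter) and a 1.5-fold higher number from compound 2 to compound 3 (0.19 log units; within the scatter). All three numbers sit within the scatter of one another.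

Compound 4 `COc1cc(/C=C2\CCC/C(=C\c3ccc(OC)c(OC)c3)C2=O)ccc1O` is not yet measured and differs from compound 3 by methoxy in place of chloro on an aromatic carbon. This is the same kind of change as that from compound 1 to compound 2, though the surroundings differ: in compound 1 the exchanged atom sits ortho to a large group, in compound 3 ortho to a hydroxy group (1 heavy atom) and meta to a large group. Because a 1.3-fold lower number from compound 1 to compound 2 (0.11 log units; within the scatter) stayed within the scatter, the step from compound 3 to compound 4 is expected to be small, about a 1.3-fold lower number from compound 3 to compound 4 (0.11 log units; within the scatter). Compound 4 is therefore estimated at 9500 nM in this assay, likely between 4500 nM and 20000 nM.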

Compound 4, half-maximal inhibitory concentration: 7900 nM
Beside the measured number, compound 4's estimate is 1.2-fold (0.08 log units) above it; low and high end bracket the measured number.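

In this assay, methoxy in place of chloro on an aromatic carbon gives a 1.6-fold lower number from compound 3 to compound 4 (0.19 log units; within the scatter), and the two occurrences of this exchange do not differ: the same change on two cores in this assay, a 1.3-fold lower number (0.11 log units; within the scatter) from compound 1 to compound 2 and a 1.6-fold lower number (0.19 log units; within the scatter) from compound 3 to compound 4, 1.2-fold (0.08 log units) apart, within the scatter of two such steps. Among these compounds, the two further steps to compound 4, a 1.0-fold lower number from compound 2 to compound 4 (0.01 log units; within the scatter) and a 1.3-fold lower number from compound 1 to compound 4 (0.12 log units; within the scatter), are also within the scatter, so no pair among the four compounds is separated beyond it. The exchange therefore carries across these two cores as a step too small to read, but this does not show that it has a real effect on either core, nor that it would stay as small on any other core.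

The compounds shown leave open whether a different group on the aromatic ring, such as an amine or a carboxylic acid, would move the number beyond the scatter. Also open, from the compounds shown here alone, is whether a longer chain in place of the methoxy of the 4-hydroxy-3-methoxyphenyl arm would separate any compound from the rest.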